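The source may hold more compounds than are shown below. What is called first, only, known or untested is meant among the compounds shown, and "the series" means these compounds.

Compound 1 `CCc1ccccc1C(=O)Nc1c[nH]nc1C(=O)N[C@H]1CC[C@H](OC)CC1`: 3400 nM
Compound 2 `COc1cccc(OC)c1C(=O)Nc1c[nH]nc1C(=O)NC1CC1`: > 50000 nM
Compound 3 `CO[C@H]1CC[C@H](NC(=O)c2n[nH]cc2NC(=O)c2ccc(N3CCCC3)cc2)CC1`: > 50000 nM

Of the compounds shown here, three sharing one core have been tested in an ADME assay on MRC5 cells (Homo sapiens) for inhibition, with a stated time of 72 h; on this read-out lower numbers stand for an effect already at smaller amounts and higher numbers for an effect only at larger amounts of compound. Compound 1 gives 3400 nM. For compound 2 the result is > 50000 nM, which is a limit of the assay and not a number. Compound 3 likewise reaches only a limit, > 50000 nM. Compound 2 therefore stands at the limit of > 50000 nM in this assay, at which 2 of the 3 values shown sit, with no effect seen within the tested range.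

Compound 4 `COc1cccc(OC)c1C(=O)Nc1c[nH]nc1C(=O)NCCN1CCCC1` is not yet measured. It differs from compound 2 in a single place: 2-(pyrrolidin-1-yl)ethyl in place of cyclopropyl on an amide-type nitrogen. Among the compounds with values here, no pair of measured compounds differing in one place is available, so the size of such a step cannot be read from the measured compounds. Since compound 2 sits at the limit with > 50000 nM, the step can only appear as staying at the limit or as moving toward smaller amounts. The expected step is an at least 1.6-fold lower number from compound 2 to compound 4 (0.22 log units; that floor lies within the scatter), a move toward smaller amounts that is close to the usual scatter. Compound 4 is thus expected at 30000 nM, in a range from 8000 nM to 50000 nM, with a real chance that only a limit is again reported.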

Compound 4, half-maximal effective concentration: > 50000 nM
Compound 4 gave a limit, no number (the forecaster's own chance of this, stated with the estimate: 50%); middle value at least 1.6-fold (0.22 log units) from the limit.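

Compound 2 and compound 4 both end at a limit of the assay, and no step between them can be read: the limit of > 50000 nM in this assay, at which 3 of the 4 values shown sit.

The compounds shown leave open whether 2-(pyrrolidin-1-yl)ethyl in place of cyclopropyl on an amide-type nitrogen shifts this read-out at all.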